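From ethoxycarbonyl to methyl on a carbonyl carbon

The source may hold more compounds than are shown below. What is called first, only, known or untested is meant among the compounds shown, and "the series" means these compounds.

- Compound 1 `COc1cc(/C=C/C(=O)c2cccc(NC(=O)c3ccc(Cl)cc3Cl)c2)ccc1O` gives 12.8 ug/mL
- Compound 2 `CCOC(=O)C(=O)Nc1cccc(C(=O)/C=C/c2ccc(O)c(OC)c2)c1` gives 7.03 ug/mL

Only these two numbers exist so far in a functional assay on B16 cells (Mus musculus) for inhibition; on this read-out higher numbers stand for weaker inhibition and lower numbers for stronger inhibition. Among the measured compounds shown here, compound 2 (7.03 ug/mL) therefore stands within the scatter of compound 1, its only neighbour. Compound 3 `COc1cc(/C=C/C(=O)c2cccc(NC(C)=O)c2)ccc1O` has not been measured. It differs from compound 2 as follows: methyl in place of ethoxycarbonyl on a carbonyl carbon. For the measured compounds named here, one measured step bears on this change, since it also concerns ethoxycarbonyl on a carbonyl carbon: a 1.8-fold lower number from compound 1 to compound 2 (0.26 log units; within the scatter). That step replaced a much larger group and stayed within the scatter, so no step beyond the scatter is expected here, though a single step is thin evidence. The expected step is a 1.3-fold higher number from compound 2 to compound 3 (0.11 log units; within the scatter) (an estimate). The estimated value for compound 3 is 9 ug/mL (expected range 4 ug/mL to 22 ug/mL).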

Compound 3, half-maximal inhibitory concentration: 3.62 ug/mL
Compound 3: the middle estimate sits 2.5-fold (0.40 log units) above what was measured; the measured number lies below the stated range.
By their numbers in this assay, from the lowest: compounds 3, 2 and 1 (each within the scatter of the next, the first and the last beyond it).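

In this assay, methyl in place of ethoxycarbonyl on this carbonyl carbon gives a 1.9-fold lower number from compound 2 to compound 3 (0.29 log units; within the scatter), so compound 2 and compound 3 cannot be told apart, and the ester is shown to be dispensable here. Methyl in place of 2,4-dichlorophenyl gives a 3.5-fold lower number from compound 1 to compound 3 (0.55 log units; beyond the scatter), the first modest change at this position to pass beyond the scatter, showing that a lone methyl on the carbonyl carbon bonded to the amide-type nitrogen retains inhibition and that the dichlorinated aromatic ring is not required for it. No measurement shown explains this difference. The compounds shown leave open whether an ethyl or a longer chain on this carbonyl carbon would keep this level of inhibition. They also leave open how a carboxylic acid in place of the ethyl ester, or a free amine in place of the acetamido group, would read in this assay.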